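This account rests on a few compounds, and the source may have more. Where it says the series, first, only, none or still open, it means among the compounds named here.

Compound 1 `Cc1cc(Nc2cc(N3CCN(C)CC3)nc(Nc3ccc(Cl)cc3)n2)n[nH]1`: 53.1 nM
Compound 2 `Cc1cc(Nc2cc(N3CCN(C)CC3)nc(Nc3cccc([N+](=O)[O-])c3)n2)n[nH]1`: 26 nM

In a functional assay on MOLT-4 cells (Homo sapiens) for antiproliferative activity, read by CCK-8 assay, with a stated time of 72 h (on this read-out higher numbers stand for weaker inhibition and lower numbers for stronger inhibition), compound 2 stands at the lower of the two numbers, and compound 1 sits at the higher one with 53.1 nM. Among the compounds with values here, the single measured step between them is a 2.0-fold lower number from compound 1 to compound 2 (0.31 log units; beyond the scatter), brought about by 3-nitrophenyl in place of 4-chlorophenyl on a nitrogen on an aromatic ring. Compound 3 `Cc1cc(Nc2cc(N3CCN(C)CC3)nc(Nc3ccc(C#N)cc3)n2)n[nH]1` has not been measured; it differs from compound 2 by 4-cyanophenyl in place of 3-nitrophenyl on a nitrogen on an aromatic ring. The measured step bears on this only indirectly: it also exchanges one group on that same ring for another, and the change it produced was a 2.0-fold lower number from compound 1 to compound 2 (0.31 log units; beyond the scatter), a modest amount. Nothing shows how 4-cyanophenyl compares with 3-nitrophenyl, so a step of at most similar size is expected in this assay, in either direction, most likely within the scatter. Compound 3 is therefore estimated at 40 nM, with a range from 15 nM to 120 nM. This estimate corresponds to an expected step of a 1.5-fold higher number from compound 2 to compound 3 (0.19 log units; within the scatter).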

Compound 3, half-maximal inhibitory concentration: 13.6 nM
Beside the measured number, compound 3's estimate is 2.9-fold (0.47 log units) above it; the whole stated range lies above it.
By their numbers in this assay, from the lowest: compounds 3 and 2 (each within the scatter of the next); then compound 1.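

In this assay, 4-cyanophenyl in place of 3-nitrophenyl on this nitrogen gives a step within the scatter (a 1.9-fold lower number from compound 2 to compound 3 (0.28 log units; within the scatter)), so the two groups cannot be told apart here. The comparison with compound 1 is cleaner, since 4-chlorophenyl and 4-cyanophenyl differ only by cyano in place of chloro on an aromatic carbon (a 3.9-fold lower number from compound 1 to compound 3 (0.59 log units; beyond the scatter)), a modest step beyond the scatter. Within the data shown here, the earlier step changed both the group and the number in its name, so this is the first comparison of two groups alone.

Still open, going by these compounds, is how 3-cyanophenyl would compare, which would separate the group from its place on the ring. Also open, on these data alone, is how plain phenyl or 4-methoxyphenyl would fare on this nitrogen. No measurement here explains either step.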